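The source may report more compounds than this note shows. Statements on the series, on what has been measured and on what is new or still open speak of the compounds shown alone.

Two amides on a shared core have been measured. Compound 1 `Cc1nn(Cc2cccc(C(=O)Nc3ccccc3)c2)c(C)c1NC(=O)c1ccc(COc2ccccc2)cc1` gives 6400 nM in a functional assay on MIA PaCa-2 cells (Homo sapiens) for antiproliferative activity, read by MTT assay, with a stated time of 72 h; a lower number here means that less compound is needed, a higher number that more compound is needed for the effect. Compound 2 `CNC(=O)c1cccc(Cn2nc(C)c(NC(=O)c3ccc(COc4ccccc4OC)cc3)c2C)c1` gives 8500 nM in this assay, and the two values sit within the usual scatter of one another, so neither compound can be set apart from the other on these numbers. Compound 3 `CNC(=O)c1cccc(Cn2nc(C)c(NC(=O)c3ccc(COc4ccccc4C(F)(F)F)cc3)c2C)c1` is the next compound to be measured; it differs from compound 2 by trifluoromethyl in place of methoxy on an aromatic carbon. For the measured compounds named here, no measured pair shows what this change does. The step from compound 2 to compound 3 is expected to be small, a 1.1-fold lower number from compound 2 to compound 3 (0.05 log units; within the scatter), with no clear direction. For compound 3 the expected value is 7500 nM, in the range 2500 nM to 22000 nM.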

Compound 3, half-maximal effective concentration: 10000 nM
Compound 3: the middle estimate sits 1.3-fold (0.12 log units) below what was measured; measured number inside the range.
By their numbers in this assay, from the lowest: compounds 1, 2 and 3 (each within the scatter of the next).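

With this assay, trifluoromethyl in place of methoxy on an aromatic carbon, ortho to a large group, gives a 1.2-fold higher number from compound 2 to compound 3 (0.07 log units; within the scatter), the first step read at this position. On this single pair, the two groups cannot be told apart here. No measurement on hand bears on this result.

Going by these compounds, whether an amine or a carboxylic acid on this carbon would give a different number remains open. Compound 1 differs from compound 2 and compound 3 in more than one place, so it offers no readable step for a hydrogen here.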